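Notes on a chain isomer of compound 2

This account rests on a few compounds, and the source may have more. Where it says the series, first, only, none or still open, it means among the compounds named here.

For the measured compounds named here, in a functional assay for inhibition, with Rattus norvegicus as the target (on this read-out higher numbers stand for weaker inhibition and lower numbers for stronger inhibition), compound 2 (`CC(N/C(=C\[N+](=O)[O-])Nc1cccnc1)C(C)(C)C`) gives 31.6 nM and holds the lower of the two numbers so far. Compound 1 (`CC(C)(C)CN/C(=C\[N+](=O)[O-])Nc1cccnc1`) stands higher at 1000 nM on the same read-out. Compound 3 (`CC(C)(C)CCN/C(=C\[N+](=O)[O-])Nc1cccnc1`) is not yet measured and carries 3,3-dimethylbutyl in place of 1,2,2-trimethylpropyl on an amine nitrogen. Going by the values given here, one measured step bears on this: the large 32-fold lower number from compound 1 to compound 2 (1.50 log units; beyond the scatter) came with methyl in place of hydrogen on a saturated chain carbon bound to an amine nitrogen. Compound 3 again has hydrogen on that carbon, but its chain is not that of compound 1, so only part of that step is expected to be undone. The expected change is a 9.5-fold higher number from compound 2 to compound 3 (0.98 log units; beyond the scatter) toward weaker inhibition. Compound 3 is estimated at 300 nM with an expected range from 80 nM to 1200 nM in this assay.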

Compound 3, half-maximal inhibitory concentration: 2000 nM
Compound 3: the middle estimate sits 6.7-fold (0.82 log units) below what was measured; measured number above the stated range.
By their numbers in this assay, from the lowest: compound 2; then compounds 1 and 3 (each within the scatter of the next).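

With the same atoms joined differently, 3,3-dimethylbutyl in place of 1,2,2-trimethylpropyl on the amine nitrogen gives a 63-fold higher number from compound 2 to compound 3 (1.80 log units; beyond the scatter) in this assay, so at this position the arrangement of the chain matters, not only its atom content. The step of a 2.0-fold higher number from compound 1 to compound 3 (0.30 log units; within the scatter) lies within the scatter, so neopentyl in place of tert-butyl on the saturated chain carbon leaves the read-out unresolved, and among these three compounds only compound 2, with its methyl on the carbon bound to the amine nitrogen, stands apart. No available evidence accounts for this difference.

Still open, from the compounds shown here alone, is whether that methyl alone suffices, which a smaller 1-methylpropyl or isopropyl group on the same nitrogen would test. Whether an ethyl group in its place, or a ring such as cyclopentyl, holds the low number also remains unresolved.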